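The source may hold more compounds than are shown below. What is called first, only, known or untested is meant among the compounds shown, and "the series" means these compounds.

Among the measured compounds shown here, in a functional assay on CAL-51 cells (Homo sapiens) for antiproliferative activity, read by luminescence and CellTiter-Glo, with a stated time of 3 days (on this read-out higher numbers stand for weaker inhibition and lower numbers for stronger inhibition), compound 1 (`C[C@@H](Oc1cc(C(=O)N(C)C)ccc1Nc1nc(O[C@H]2CC[C@@](C)(O)CC2)c2cc[nH]c2n1)C(F)(F)F`) gives 24 nM and compound 2 (`CN(C)C(=O)c1ccc(Nc2nc(O[C@H]3CC[C@@](C)(O)CC3)c3cc[nH]c3n2)c(OCC(F)(F)F)c1`) gives 15 nM as the only other number, so compound 1 stands within the scatter of its one neighbour. Compound 3 (`COc1cc(C(=O)N(C)C)ccc1Nc1nc(O[C@H]2CC[C@@](C)(O)CC2)c2cc[nH]c2n1`) awaits measurement and differs from compound 1 by methyl in place of 1-(trifluoromethyl)ethyl on an oxygen on an aromatic ring with methyl in place of 1-(trifluoromethyl)ethyl on an oxygen on an aromatic ring. For the measured compounds named here, the one measured step that bears on this is a 1.6-fold lower number from compound 1 to compound 2 (0.20 log units; within the scatter) and it leaves the trifluoromethyl in place, so the data do not test its removal. In this assay, going by the values given here, no step clearly beyond the scatter is therefore expected, with a slight lean to a higher number. The estimated step is a 1.5-fold higher number from compound 1 to compound 3 (0.16 log units; within the scatter) on this reading. Compound 3 is expected at 35 nM with an estimated range of 12 nM to 110 nM in this assay.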

Compound 3, half-maximal inhibitory concentration: 44 nM
Compound 3: middle estimate off by 1.3-fold (0.10 log units), on the low side; low and high end bracket the measured number.
By their numbers in this assay, from the lowest: compounds 2, 1 and 3 (each within the scatter of the next, the first and the last beyond it).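

Methyl in place of 1-(trifluoromethyl)ethyl on an oxygen on an aromatic ring gives a 1.8-fold higher number from compound 1 to compound 3 (0.26 log units; within the scatter) in this assay, so even this exchange of the whole group stays inside the usual spread of the measurement. Hydrogen in place of trifluoromethyl on the saturated chain carbon bound to that oxygen gives a 2.9-fold higher number from compound 2 to compound 3 (0.47 log units; beyond the scatter), the only step among these compounds that passes the scatter, and only modestly. Removing the trifluoromethyl, left untested by the earlier pair, thus separates compound 3 clearly from compound 2 but not from compound 1. The compounds shown leave open how an ethyl group, a longer chain or a chain ending in an amine would read on this oxygen. They also leave open what the opposite configuration at the defined stereocentre of compound 1 would give. Nothing available here explains these differences.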